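The source may hold more compounds than are shown below. What is called first, only, known or untested is meant among the compounds shown, and "the series" means these compounds.

In an ADME assay on HEK293 cells (Homo sapiens) for cytotoxicity, read by MTT assay, with a stated time of 48 h (on this read-out higher numbers stand for weaker inhibition and lower numbers for stronger inhibition), compound 2 `CS(=O)(=O)Nc1ccc(NC(=O)c2ccc(Cl)c([N+](=O)[O-])c2)cc1Cl` gives 204000 nM and compound 1 `COc1cc(NC(=O)c2ccc(Cl)c([N+](=O)[O-])c2)ccc1NS(C)(=O)=O` gives 164000 nM, two numbers within the scatter of each other. Going by the values given here, the one measured step, a 1.2-fold higher number from compound 1 to compound 2 (0.09 log units; within the scatter), stays within the scatter. Compound 3 `O=C(Nc1ccc(NS(=O)(=O)C(F)(F)F)c(Cl)c1)c1ccc(Cl)c([N+](=O)[O-])c1` differs from compound 2 by trifluoromethyl in place of methyl on a sulfonyl sulfur. Among the compounds with values here, no measured step touches the sulfonyl substituent, so no step bears directly on this change; the single step available gives no sign of movement. For compound 3 in this assay the expected step is a 1.0-fold lower number from compound 2 to compound 3 (0.01 log units; within the scatter), which stays within the scatter. Compound 3 is estimated at 200000 nM, with a range from 100000 nM to 400000 nM.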

Compound 3, half-maximal inhibitory concentration: 228000 nM
Estimate against measurement, compound 3: 1.1-fold (0.06 log units) below, and the stated range covers the measured number.
By their numbers in this assay, from the lowest: compounds 1, 2 and 3 (each within the scatter of the next).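

With trifluoromethyl in place of methyl on a sulfonyl sulfur, this assay shows a 1.1-fold higher number from compound 2 to compound 3 (0.05 log units; within the scatter). The sulfonyl substituent therefore now has a measured step of its own, and the exchange of methyl for trifluoromethyl leaves the number unmoved, as the chloro for methoxy exchange on the aromatic carbon did. Nothing available offers an explanation of this result.

Still open, from the compounds shown here alone, is whether a longer chain or a phenyl ring on the sulfonyl sulfur would also leave the number unmoved. An amine at that place is equally untested in the compounds shown.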